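The source may report more compounds than this note shows. Statements on the series, on what has been measured and on what is new or still open speak of the compounds shown alone.

Compound 1 `COC(=O)c1ccc(OCCCOc2ccc3c(O)c([N+](=O)[O-])c(=O)oc3c2)cc1`: > 10000 nM
Compound 2 `O=c1oc2cc(OCCCOc3ccc(-c4ccccc4)cc3)ccc2c(O)c1[N+](=O)[O-]`: > 20000 nM

In a functional assay on ileum (Cavia porcellus) for antagonist activity (on this read-out higher numbers stand for weaker inhibition and lower numbers for stronger inhibition), compound 2 reads > 20000 nM, which is a limit of the assay and not a number. Compound 1 reads > 10000 nM, which is also a limit. Neither compound therefore has an exact potency to build on.

Compound 3 `O=C(O)c1ccc(OCCCOc2ccc3c(O)c([N+](=O)[O-])c(=O)oc3c2)cc1` keeps the shared core and puts carboxy in place of phenyl on an aromatic carbon, para to a large group: carboxy in place of phenyl on an aromatic carbon.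

Among the measured compounds shown here, the only measured step bearing on this place is a step that the two limits leave unreadable from compound 1 to compound 2. It gives no size to carry over, so any expectation here is loose. A large gain in this assay is not expected, though a modest move towards stronger inhibition is possible.

For compound 3 the expected value is 10000 nM, with an estimated range from 1500 nM to 30000 nM. The expected change is an at least 2.0-fold lower number from compound 2 to compound 3 (0.30 log units; that floor lies within the scatter).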

Compound 3, half-maximal inhibitory concentration: > 20000 nM
Compound 3 ended at the assay's limit (the forecaster's own chance of this, stated with the estimate: 60%); middle value at least 2.0-fold (0.30 log units) away from the limit.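

Among the compounds shown here, compound 1, compound 2 and compound 3 all stand at limits in this assay and not at exact numbers, so no step among them can be read. The compounds shown leave open how strongly each one inhibits, and whether swapping these groups changes that at all.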